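Swapping bromine for chlorine on the benzyl ring

This account rests on a few compounds, and the source may have more. Where it says the series, first, only, none or still open, it means among the compounds named here.

Measured compounds:
compound 1 `Cc1ccccc1CN1CC=C(CCC(=O)NO)C1=O` — 1990 nM
compound 2 `Cc1cccc(CN2CC=C(CCC(=O)NO)C2=O)c1` — 1990 nM
compound 3 `O=C(CCC1=CCN(Cc2cccc(Br)c2)C1=O)NO` — 1990 nM

In a functional assay on MDA-MB-231 cells (Homo sapiens) for inhibition, read by sulforhodamine B assay (on this read-out lower numbers stand for stronger inhibition of growth and higher numbers for weaker inhibition of growth), compound 3 gives 1990 nM. This puts it level with compound 1 at 1990 nM and level with compound 2 at 1990 nM; the three values cannot be told apart within the scatter of this assay. The shared core, a hydroxamic acid chain on an unsaturated lactam, carries a benzyl group whose ring substituent is the only thing that varies.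

Compound 4 `O=C(CCC1=CCN(Cc2cccc(Cl)c2)C1=O)NO` is the next member. Its difference from compound 3 is chloro in place of bromo on an aromatic carbon. Among the measured compounds shown here, one measured step bears on it: no change at the digits printed from compound 2 to compound 3 (within the scatter), where a methyl gave way to a bromo on an aromatic carbon and the value did not move. A substituent change of that kind at this ring position has thus left growth inhibition untouched, and replacing one halogen with another is a smaller structural move than methyl to bromo.

Compound 4 is therefore expected to give 1990 nM, with a likely range from 1000 nM to 4000 nM. The expected step is no change at the digits printed from compound 3 to compound 4 (within the scatter), that is, no change beyond the scatter.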

Compound 4, concentration for 50% growth inhibition: 1990 nM
For compound 4 middle estimate and measured number coincide at the digits printed, and the stated range covers the measured number.
By their numbers in this assay, from the lowest: compounds 1, 2, 3 and 4 (each within the scatter of the next).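

In this assay, the new compound brings a second halogen to this place on the benzyl ring: chloro in place of bromo gives no change at the digits printed from compound 3 to compound 4 (within the scatter) and chloro in place of methyl gives no change at the digits printed from compound 2 to compound 4 (within the scatter) on the same kind of aromatic carbon. Where the earlier compounds offered only a single pair at this place, methyl and bromo, there are now three groups, methyl, bromo and chloro, that this read-out cannot tell apart, and the exchange of one halogen for another joins the exchange of methyl for a halogen as a swap that leaves growth inhibition where it was. Nothing measured here offers a reason for this flat result, so it stands as an observation only.

The compounds shown leave open whether the read-out would hold with a very different group at this place, such as an amine, a carboxylic acid or a longer chain, and three matching groups cannot settle whether this place matters at all. They also leave open what a change to the hydroxamic acid chain or to the rest of the shared core would do, as all the compounds here keep both.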